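A bromine atom added to two inactive cores

The source may report more compounds than this note shows. Statements on the series, on what has been measured and on what is new or still open speak of the compounds shown alone.

Measured so far:
Compound 1, `Cc1ccnc(OCc2ccc(F)cc2)c1C(=O)NC1CCCCCC1`, in an ADME assay on cells for inhibition of Fatty-acid amide hydrolase 1 (Homo sapiens), with stated times of 30 min and 15 min (a lower number here means a stronger inhibitor, a higher number a weaker inhibitor), gives a limit of the assay, > 10000 nM.
Compound 2, `O=C(NC1CCCCCC1)c1c(-c2ccccc2)c(Br)cn(Cc2ccc(F)cc2)c1=O`, in this assay gives a limit, > 10000 nM.
Compound 3, `O=C(NC1CCCCCC1)c1c(-c2ccccc2)ccn(Cc2ccc(F)cc2)c1=O`, in this assay gives a limit, > 10000 nM.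

All three values sit at the limit of > 10000 nM in this assay, at which 3 of the 3 values shown sit, so none of them is a number. Compound 3 and compound 2 are related by a single change, (bromo in place of hydrogen on an aromatic carbon), and the step that the two limits leave unreadable from compound 3 to compound 2 cannot be read from two limits. How the core of compound 1 and the core of compound 3 differ is not broken down here.

The unmeasured compound 4, `Cc1c(Br)cnc(OCc2ccc(F)cc2)c1C(=O)NC1CCCCCC1`, arises from compound 1 by the same kind of change, (bromo in place of hydrogen on an aromatic carbon). The surroundings of the place are not identical: in compound 2 the bromo sits ortho to a phenyl group, meta to a 4-fluorobenzyl group, meta to a cycloheptylcarbamoyl group and para to a group of 1 heavy atom, whereas in compound 4 it sits ortho to a methyl group, meta to a large group and para to a (4-fluorobenzyl)oxy group.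

Among the compounds with values here, because compound 1 gives > 10000 nM, a limit, and because the only comparable step is a step that the two limits leave unreadable from compound 3 to compound 2, no size can be taken over. The step that the limit leaves unreadable from compound 1 to compound 4 is therefore expected to be small. Compound 4 is expected to give about 20000 nM in this assay, most likely again reported only as a limit, with a range from 7000 nM to 100000 nM.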

Compound 4, half-maximal inhibitory concentration: > 10000 nM
Compound 4 was reported as a limit (the forecaster's own chance of this, stated with the estimate: 85%); the middle value does not contradict the limit.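

Compound 1 and compound 4 differ only by bromo in place of hydrogen on an aromatic carbon, but no size can be read for this step, since both compounds stand only as limits: the limit of > 10000 nM in this assay, at which 4 of the 4 values shown sit.

The compounds shown leave open how strongly compound 1, compound 2, compound 3 and compound 4 inhibit the enzyme, and whether bromo changes that inhibition on either core.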